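From tert-butyl to cyano: expecting a whole-organism value

A few compounds are considered here, and "the series" means these few. Any claim that something is new, unique, unknown or untested is made for them only; others in the source may bear on it.

Two compounds have been tested so far in a functional assay with Rattus norvegicus as the target; on this read-out higher numbers stand for weaker inhibition and lower numbers for stronger inhibition:

compound 1, `CC(C)(C)c1ccc(C(=O)/C=C/c2ccncc2)cc1`, which gives 47000 nM
compound 2, `O=C(/C=C/c1ccncc1)c1cccs1`, which gives 30000 nM

Compound 1 stands at one end of this pair, but its gap to compound 2 falls within the usual scatter of repeated measurements, so the two cannot be told apart and neither can be called the stronger or weaker inhibitor. Both sit at weak inhibition.

Compound 3, `N#Cc1ccc(C(=O)/C=C/c2ccncc2)cc1`, has not yet been measured in this assay. It differs from compound 1 in a single place: cyano in place of tert-butyl on an aromatic carbon. Among the measured compounds shown here, no measured pair shows what such a change does on this read-out, so the data give no direction to lean toward. The expected step is a 1.2-fold lower number from compound 1 to compound 3 (0.07 log units; within the scatter), which is none beyond the scatter. Compound 3 is therefore expected to give 40000 nM in this assay, with a range from 10000 nM to 150000 nM.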

Compound 3, half-maximal inhibitory concentration: 123000 nM
Beside the measured number, compound 3's estimate is 3.1-fold (0.49 log units) below it, and the stated range covers the measured number.
By their numbers in this assay, from the lowest: compounds 2 and 1 (each within the scatter of the next); then compound 3.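

In this assay cyano in place of tert-butyl on an aromatic carbon gives a 2.6-fold higher number from compound 1 to compound 3 (0.42 log units; beyond the scatter) and so moves toward weaker inhibition. Among the compounds shown here, this is the first sign that the read-out responds to what sits at this place on the shared core, since compound 1 and compound 2 could not be told apart. Nothing available explains why the number rises with this change.

This single pair cannot separate the effect of having fewer heavy atoms at this place from that of bringing in a hydrogen-bond acceptor. It also leaves open whether a group such as an amine, a methoxy or a longer alkyl chain at the same place would stay near compound 1, approach compound 3 or reach stronger inhibition than either.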